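Shortening the Chain Beyond the Sulfur in Compound 3

The compounds below may be only part of what the source reports. "The series", "measured", "known", "first", "only" and "open" are said of these compounds alone.

Compound 3 `CCCCCCCCSCC1C2CCC(O2)C1C/C=C\CCCC(=O)O` gives 547000 nM in a functional assay on a cell-free system (plasma) for inhibition of thromboxane A2 receptor (Homo sapiens) (a higher number here means a weaker inhibitor, a lower number a stronger inhibitor), the highest of the two single numbers recorded there. Its nearest neighbour is compound 1 `CCCCSCSCC1C2CCC(O2)C1C/C=C\CCCC(=O)O`, which in this assay gives 700 nM; compound 2 `CCCCCCCSC1C2CCC(O2)C1C/C=C\CCCC(=O)O` stands apart with 230000 nM; 35000 nM (2 entries), and the several entries of compound 2 in this assay, 230000 nM; 35000 nM (2 entries) shows how widely its repeat entries spread. The step of a 780-fold higher number from compound 1 to compound 3 (2.89 log units; beyond the scatter) is the only measured one that bears on compound 3. Compound 4 `CCCCSCC1C2CCC(O2)C1C/C=C\CCCC(=O)O` differs from compound 3 by hydrogen in place of butyl on a saturated chain carbon, four bonds along the chain from a sulfur. That change trims the chain back toward the butylsulfanyl unit present in compound 1, whose value of 700 nM sits far lower, so in this assay a large step downward is expected for compound 4. Compound 4 is therefore estimated at 40000 nM, ranging from 3000 nM to 400000 nM, a step of a 14-fold lower number from compound 3 to compound 4 (1.14 log units; beyond the scatter).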

Compound 4, half-maximal inhibitory concentration: 1000 nM
The estimate for compound 4 lay 40-fold (1.60 log units) above the measured number; the whole stated range lies above it.
By their numbers in this assay, from the lowest: compounds 1 and 4 (each within the scatter of the next); then compound 3.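

Hydrogen in place of butyl, four bonds along the chain from a sulfur, is a large change at this place in this assay: a 550-fold lower number from compound 3 to compound 4 (2.74 log units; beyond the scatter). Propyl in place of butylsulfanyl leaves the two short-chain compounds within the scatter, so a low number here does not depend on the butylsulfanyl group: a 1.4-fold higher number from compound 1 to compound 4 (0.15 log units; within the scatter). Nothing measured here gives a cause for the change from the longer chain to the shorter one. The compounds shown do not tell how the number moves with a pentyl or hexyl chain in place of the butyl chain of compound 4, nor whether an ether oxygen can replace its sulfur.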